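This account rests on a few compounds, and the source may have more. Where it says the series, first, only, none or still open, it means among the compounds named here.

Measured so far in an ADME assay on THP-1 cells (Homo sapiens) for cytotoxicity; a lower number here means a stronger inhibitor, a higher number a weaker inhibitor:
- compound 1 `COc1ccccc1-c1nnc(-c2ccc(C(=O)N/N=C/c3cccc(F)c3)cc2)o1` gives 353000 nM
- compound 2 `COc1ccccc1-c1nnc(-c2ccc(C(=O)N/N=C/c3cccc([N+](=O)[O-])c3)cc2)o1` gives 119000 nM
- compound 3 `COc1ccccc1-c1nnc(-c2ccc(C(=O)N/N=C/c3ccc(F)cc3)cc2)o1` gives 427000 nM

Compound 3 has the highest number of the three. Its nearest neighbour is compound 1, with a 1.2-fold higher number from compound 1 to compound 3 (0.08 log units; within the scatter), a gap inside the scatter, so the two cannot be ranked. Compound 2 lies furthest away, with a 3.6-fold higher number from compound 2 to compound 3 (0.55 log units; beyond the scatter).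

Compound 4 `COc1ccccc1-c1nnc(-c2ccc(C(=O)N/N=C/c3ccc(O)c(O)c3)cc2)o1` differs from compound 3 in one place: 3,4-dihydroxyphenyl in place of 4-fluorophenyl on a carbon with a double bond to nitrogen. Within the data shown here, no measured step swaps in a hydroxyl, so the only guidance is indirect. The step from compound 1 to compound 3 shows that moving a single substituent changed little, while the step from compound 2 to compound 3 shows that a different polar group shifted the number by a modest amount. The expected step is therefore small, at most modest, and its direction is uncertain: a 1.4-fold lower number from compound 3 to compound 4 (0.15 log units; within the scatter). Compound 4 is estimated at 300000 nM, within a range from 100000 nM to 900000 nM in this assay.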

Compound 4, half-maximal inhibitory concentration: 100000 nM
For compound 4 the middle estimate is 3.0-fold (0.48 log units) above the measured one; the range from low to high includes it.
By their numbers in this assay, from the lowest: compounds 4 and 2 (each within the scatter of the next); then compounds 1 and 3 (each within the scatter of the next).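

Set against the 4-fluorophenyl and 3-fluorophenyl groups at this position, 3,4-dihydroxyphenyl gives a shift beyond the scatter, with a 4.3-fold lower number from compound 3 to compound 4 (0.63 log units; beyond the scatter) and a 3.5-fold lower number from compound 1 to compound 4 (0.55 log units; beyond the scatter) both counting as modest. The 3-nitrophenyl group is therefore not alone in giving a lower number here, and a 1.2-fold lower number from compound 2 to compound 4 (0.08 log units; within the scatter) means that these two compounds cannot be ranked. No measurement at hand accounts for the shift.

Still open, from the compounds shown here alone, is whether a single hydroxyl would do the same as the two in compound 4. Also open, going by these compounds, is where an amine or a carboxylic acid on this ring would fall.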